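The source may report more compounds than this note shows. Statements on the series, on what has been measured and on what is new or still open speak of the compounds shown alone.

In a functional assay on MGC-803 cells (Homo sapiens) for antiproliferative activity, read by MTT assay, with a stated time of 72 h (on this read-out higher numbers stand for weaker inhibition and lower numbers for stronger inhibition), compound 1 `CC(C)(C)c1ccc(/C=C/C(=O)c2ccc(OCC(=O)N[C@H]3CCOC3=O)cc2)cc1` gives 17200 nM. Compound 2 `O=C(COc1ccc(C(=O)/C=C/c2ccccc2)cc1)N[C@H]1CCOC1=O` gives > 64000 nM, which is a limit and not a number. Compound 3 `O=C(COc1ccc(C(=O)/C=C/c2cccc([N+](=O)[O-])c2)cc1)N[C@H]1CCOC1=O` gives > 64000 nM, also a limit and not a number. Compound 3 therefore stands at the limit of > 64000 nM in this assay, at which 2 of the 3 values shown sit.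

Compound 4 `O=C(COc1ccc(C(=O)/C=C/c2ccc(Br)cc2)cc1)N[C@H]1CCOC1=O` differs from compound 3 in one place, on a double-bonded chain carbon bound to a double-bonded chain carbon, with 4-bromophenyl in place of 3-nitrophenyl on a double-bonded chain carbon bound to a double-bonded chain carbon.

Within the data shown here, two measured steps bear on this change: an at least 3.7-fold higher number from compound 1 to compound 2 (0.57 log units; beyond the scatter) and an at least 3.7-fold higher number from compound 1 to compound 3 (0.57 log units; beyond the scatter). Among the measured compounds shown here, both lead away from the 4-(tert-butyl)phenyl of compound 1, the only compound with a real number, and both are beyond the scatter. The third step, a step that the two limits leave unreadable from compound 2 to compound 3, gives no usable size.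

A modest move towards stronger inhibition is thus expected, though another limit is quite possible. The estimated step is an at least 1.6-fold lower number from compound 3 to compound 4 (0.20 log units; that floor lies within the scatter). Compound 4 is expected at 40000 nM, with an estimated range of 18000 nM to 80000 nM.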

Compound 4, half-maximal inhibitory concentration: 51000 nM
Compound 4: the middle estimate sits 1.3-fold (0.11 log units) below what was measured; the range from low to high includes it.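

Swapping tert-butyl for bromo on the aromatic carbon gives a 3.0-fold higher number from compound 1 to compound 4 (0.47 log units; beyond the scatter) in this assay, the first step in this series with a real number at both ends. The steps of an at least 1.2-fold lower number from compound 3 to compound 4 (0.09 log units; that floor lies within the scatter) and an at least 1.2-fold lower number from compound 2 to compound 4 (0.09 log units; that floor lies within the scatter) are only floors that lie within the scatter, because each starts from a limit and not a number: the limit of > 64000 nM in this assay, at which 2 of the 4 values shown sit. Compound 4 is weaker than compound 1, yet it still gives a real number, so a measurable value at this position does not belong to the 4-(tert-butyl)phenyl of compound 1 alone.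

As far as these compounds go, how far compound 4 truly lies from compound 2 and compound 3 stays open, and the steps that rest on two limits cannot be read. Also open, from the compounds shown here alone, is what an amine or a carboxylic acid on the aromatic carbon in place of bromo would give.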